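Hydrogen for ethoxy on compound 3

The source may report more compounds than this note shows. Statements on the series, on what has been measured and on what is new or still open speak of the compounds shown alone.

In a functional assay on NALM-6 cells (Homo sapiens) for cytotoxicity, with a stated time of 72 h (a higher number here means that more compound is needed for the effect, a lower number that less compound is needed), compound 3 `CCOc1ccc(/C=C/[C@@](C)(/C=C/c2ccc(O)cc2)CCC=C(C)C)cc1` gives > 43400 nM, which is a limit and not a number. Compound 2 `COc1ccc(/C=C/[C@@](C)(/C=C/c2ccc(O)cc2)CCC=C(C)C)cc1` gives > 43400 nM, also a limit. Compound 1 `C=C[C@@](C)(/C=C/c1ccc(O)cc1)CC/C=C(\C)CO` gives > 43400 nM, again a limit. Compound 3 thus stands with the whole measured set at the limit of > 43400 nM in this assay, at which 3 of the 3 values shown sit, and no ranking can be read from it.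

Compound 4 `CC(C)=CCC[C@@](C)(/C=C/c1ccccc1)/C=C/c1ccc(O)cc1` differs from compound 3 by hydrogen in place of ethoxy on an aromatic carbon. This is 4-ethoxyphenyl to phenyl, with hydrogen in place of ethoxy on an aromatic carbon.

Within the data shown here, the only measured step touching this group is a step that the two limits leave unreadable from compound 2 to compound 3, and it gives no size to carry over. Among the measured compounds shown here, no measured step covers the full loss of the ethoxy, so the expectation rests on the shared limit alone, and compound 4 will most likely report a limit too. The estimated change is a step that the limit leaves unreadable from compound 3 to compound 4, with no direction expected beyond the scatter. For compound 4 the estimate is 45000 nM, with an expected range of 15000 nM to 90000 nM.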

Compound 4, half-maximal effective concentration: > 43400 nM
Compound 4: only a limit was reported; the forecaster's own chance of this, stated with the estimate: 75%; the middle value lies beyond the limit too.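

In this assay compound 4 gives > 43400 nM, a limit and not a number. Among these compounds, no step to compound 4 can be read from compound 2 or compound 3, since the series stays at one limit: the limit of > 43400 nM in this assay, at which 4 of the 4 values shown sit. From the compounds shown here alone, whether any of these changes alters cytotoxicity in this assay remains open.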